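A few compounds are considered here, and "the series" means these few. Any claim that something is new, unique, unknown or untested is made for them only; others in the source may bear on it.

Working notes on the series. Compound 1 `O=c1[nH]c(Nc2cccc(F)c2)nc2cc(Cl)ccc12` is the reference point. In an ADME assay on Vero cells (Chlorocebus sabaeus) for cytotoxicity, read by WST assay (on this read-out higher numbers stand for lower toxicity in this test and lower numbers for higher toxicity in this test), compound 1 gives > 25000 nM, which is a limit of the assay and not a number. Compound 2 `O=c1[nH]c(Nc2ccc(F)cc2F)nc2cc(Cl)ccc12` carries two fluoro groups; in this assay compound 2 gives > 25000 nM, again a limit. Compound 3 `O=c1[nH]c(Nc2cc(F)cc(F)c2)nc2cc(Cl)ccc12` is the other difluoro analogue; in this assay compound 3 gives >= 18000 nM, also a limit. The step that the two limits leave unreadable from compound 1 to compound 3 is accordingly unreadable. Compound 1 thus stands only at a limit, and the two further values are limits as well, as the limit of > 25000 nM in this assay, at which 2 of the 3 values shown sit, and the limit of >= 18000 nM in this assay, at which 1 of the 3 values shown sits, record.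

Compound 4 `O=c1[nH]c(Nc2cccc(O)c2)nc2cc(Cl)ccc12` is not yet measured. It differs from compound 1 by hydroxy in place of fluoro on an aromatic carbon. Among the measured compounds shown here, no measured step involves a hydroxy group, and the single measured step, a fluoro added to the fluoro-bearing ring, cannot be sized. The series therefore gives neither a direction nor a size for this change. For compound 4 the expectation in this assay is a value again at the limit, estimated as 30000 nM with a range from 12000 nM to 100000 nM. The expected step that the limit leaves unreadable from compound 1 to compound 4 is none beyond the scatter.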

Compound 4, half-maximal cytotoxic concentration: > 25000 nM
Compound 4 was reported as a limit; the forecaster's own chance of this, stated with the estimate: 85%; the middle value lies beyond the limit too.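

No step can be read from compound 1 to compound 4 in this assay, as both compounds stand only at a limit: the limit of > 25000 nM in this assay, at which 3 of the 4 values shown sit. The compounds shown leave open whether hydroxy in place of fluoro on an aromatic carbon shifts this read-out at all, in either direction.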